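From phenyl to 3-methylpiperidin-1-yl on compound 2

The source may report more compounds than this note shows. Statements on the series, on what has been measured and on what is new or still open speak of the compounds shown alone.

In a physicochemical assay for solubility (a lower number here means a less soluble compound, a higher number a more soluble compound), compound 1 (`CS(=O)(=O)c1ccc(-n2nc(C(F)(F)F)cc2-c2ccccc2)nc1`) gives 50 ug/mL as its reading, and compound 2 (`CS(=O)(=O)c1ccc(-n2nc(C(F)(F)F)c(C#N)c2-c2ccccc2)nc1`) gives 100 ug/mL as its reading. These two numbers lie within the scatter of each other, so compound 2 stands level with compound 1. For compound 3 (`CS(=O)(=O)c1ccc(-n2nc(C(F)F)c(C#N)c2-c2ccccc2)nc1`) the entry is "not determined" (no result reported) and it adds no number.

Compound 4 (`CC1CCCN(c2c(C#N)c(C(F)(F)F)nn2-c2ccc(S(C)(=O)=O)cn2)C1`) differs from compound 2 by one change, (3-methylpiperidin-1-yl in place of phenyl on an aromatic carbon), which in words is 3-methylpiperidin-1-yl in place of phenyl on an aromatic carbon. Among the measured compounds shown here, the one measured step, a 2.0-fold higher number from compound 1 to compound 2 (0.30 log units; within the scatter), is cyano in place of hydrogen and leaves the phenyl untouched, so it bears on this replacement only indirectly. For the measured compounds named here, with no measured step that replaces phenyl, no change beyond the scatter is expected in this assay, and the direction stays uncertain. The estimate corresponds to an expected 1.7-fold lower number from compound 2 to compound 4 (0.22 log units; within the scatter) in this reading. For compound 4 the estimated value is 60 ug/mL, with an expected range from 15 ug/mL to 200 ug/mL overall.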

Compound 4, solubility: 100 ug/mL
The estimate for compound 4 lay 1.7-fold (0.22 log units) below the measured number, within the range that was stated.
By their numbers in this assay, from the lowest: compounds 1, 2 and 4 (each within the scatter of the next).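

In this assay, replacing phenyl with 3-methylpiperidin-1-yl gives no change at the digits printed from compound 2 to compound 4 (within the scatter). Among the compounds shown here, the earlier step changed only hydrogen to cyano and kept phenyl in place, so this is the first reading of a different group at this position, on an aromatic carbon next to the ring atom that bears a cyano group. It shows that a six-membered non-aromatic ring with a hetero atom can stand here in place of a six-membered aromatic ring of carbon only with no change beyond the scatter, though nothing measured here says why.

The compounds shown leave open whether this level reading extends to other groups at this position, such as morpholin-4-yl, a primary amine or a longer alkyl chain. For the compounds shown here, they also leave open what the methyl on the piperidine ring contributes, since no compound here carries that ring without it.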